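The source may report more compounds than this note shows. Statements on the series, on what has been measured and on what is new or still open speak of the compounds shown alone.

Measured so far:
- compound 1, `CCn1c(C(=O)NCC(=O)OC)ccc1C(CC)(CC)c1ccc(OCS(=O)(=O)c2ccccc2)c(C)c1` — > 50000 nM
- compound 2, `CCn1c(C(=O)N[C@@H](CC(=O)OC)C(=O)OC)ccc1C(CC)(CC)c1ccc(OCS(=O)(=O)c2ccccc2)c(C)c1` — > 50000 nM
- compound 3, `CCn1c(C(=O)N[C@@H](CO)C(C)C)ccc1C(CC)(CC)c1ccc(OCS(=O)(=O)c2ccccc2)c(C)c1` — 18800 nM

In a functional assay on MCF7 cells (Homo sapiens) for antiproliferative activity, read by MTT assay, with a stated time of 24 h (on this read-out higher numbers stand for weaker inhibition and lower numbers for stronger inhibition), compound 1 reaches only the limit of the assay, so no number is known for it. For compound 2 the same limit is reported, and it is likewise a limit and not a number; the two sit together at the limit of > 50000 nM in this assay, at which 2 of the 3 values shown sit. Compound 3 alone gives a number, and the step of an at least 2.6-fold lower number from compound 1 to compound 3 (0.42 log units; beyond the scatter) replaces the ester-bearing group with one carrying a hydroxymethyl. The step that the two limits leave unreadable from compound 1 to compound 2 cannot be read, as both ends are limits.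

Compound 4, `CCn1c(C(=O)N[C@H](CO)CCCO)ccc1C(CC)(CC)c1ccc(OCS(=O)(=O)c2ccccc2)c(C)c1`, is not yet measured. It differs from compound 1 by a group of 7 heavy atoms (5 carbon, 2 oxygen; no ring) in place of a group of 5 heavy atoms (3 carbon, 2 oxygen; no ring), on an amide-type nitrogen. As in compound 3, the ester leaves and hydroxyls enter, so a move from the limit toward a number like that of compound 3 is expected, though a limit remains quite possible. The expected step is an at least 2.0-fold lower number from compound 1 to compound 4 (0.30 log units; that floor lies within the scatter), and compound 4 is estimated at 25000 nM, within 8000 nM to 60000 nM.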

Compound 4, half-maximal inhibitory concentration: 31400 nM
Estimate against measurement, compound 4: 1.3-fold (0.10 log units) below, within the range that was stated.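

With compound 4, a second group without the methoxycarbonyl ester gives a number in this assay, and its steps from the two ester compounds are an at least 1.5-fold lower number from compound 1 to compound 4 (0.20 log units; that floor lies within the scatter) and an at least 1.5-fold lower number from compound 2 to compound 4 (0.20 log units; that floor lies within the scatter), so taken alone these floors do not clear the scatter. The step of a 1.7-fold higher number from compound 3 to compound 4 (0.22 log units; within the scatter) means that this pair cannot be ranked, so on the amide-type nitrogen the new group and 1-(hydroxymethyl)-2-methylpropyl cannot be told apart here. Across the shown set, both groups carrying hydroxyl give numbers, while both ester compounds remain limits and not numbers: the limit of > 50000 nM in this assay, at which 2 of the 4 values shown sit.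

The compounds shown leave open what an amine or a carboxylic acid in place of the hydroxyl would do, and whether a longer chain would change the number. They also leave open how the mirror-image form of compound 4 would compare.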